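Amide aryl swap on a shared azetidine ether scaffold

The compounds below may be only part of what the source reports. "The series", "measured", "known", "first", "only" and "open" are said of these compounds alone.

Two compounds of this series have been examined in a physicochemical assay for solubility, in phosphate buffer, with a stated time of 2 h, at pH 6.5; on this read-out higher numbers stand for higher solubility and lower numbers for lower solubility. Compound 1 `CCS(=O)(=O)N1CC(Oc2cncc(N3C(=O)c4ccc(Cl)cc4C3(C)C)c2)C1` gives 78 ug/mL. Within the data shown here, compound 2 `Cn1cc(C(=O)N2CC(Oc3cncc(N4C(=O)c5ccc(Cl)cc5C4(C)C)c3)C2)cn1` gives 310 ug/mL, and the only measured step, a 4.0-fold higher number from compound 1 to compound 2 (0.60 log units; beyond the scatter), arises from (1-methyl-1H-pyrazol-4-yl)carbonyl in place of ethylsulfonyl on an amine nitrogen in a ring. Among the measured compounds shown here, on these two numbers compound 2 stands highest, with compound 1 as its only neighbour, a step beyond the scatter.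

Compound 3 `Cc1ccncc1C(=O)N1CC(Oc2cncc(N3C(=O)c4ccc(Cl)cc4C3(C)C)c2)C1` has not yet been measured. It differs from compound 2 by 4-methylpyridin-3-yl in place of 1-methyl-1H-pyrazol-4-yl on a carbonyl carbon, with the same carbonyl retained on the amide-type nitrogen in the ring. For the measured compounds named here, no measured step involves this exchange: the one step on record changes the group on the ring nitrogen itself rather than the aryl on the carbonyl carbon, so it offers no direct guide. In this assay compound 3 is therefore expected to lie close to compound 2, with a step of a 1.4-fold lower number from compound 2 to compound 3 (0.15 log units; within the scatter) that should fall within the scatter. The estimate for compound 3 is 220 ug/mL, with a range from 70 ug/mL to 500 ug/mL.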

Compound 3, solubility: 290 ug/mL
Estimate against measurement, compound 3: 1.3-fold (0.12 log units) below; low and high end bracket the measured number.
By their numbers in this assay, from the lowest: compound 1; then compounds 3 and 2 (each within the scatter of the next).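

In this assay the exchange of 1-methyl-1H-pyrazol-4-yl for 4-methylpyridin-3-yl on a carbonyl carbon gives a 1.1-fold lower number from compound 2 to compound 3 (0.03 log units; within the scatter), so at this position these two groups are not told apart, although a five-membered aromatic ring gives way to a six-membered aromatic ring. The step away from ethylsulfonyl now has a second example, since (4-methylpyridin-3-yl)carbonyl on the amine nitrogen in the ring gives a 3.7-fold higher number from compound 1 to compound 3 (0.57 log units; beyond the scatter), which shows that the result beyond the scatter is not confined to the (1-methyl-1H-pyrazol-4-yl)carbonyl group, and among these three compounds neither carbonyl compound goes against it. The data shown offer no measured explanation for either step.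

The compounds shown leave open whether the 4-methyl group on the pyridine contributes anything to this read-out, which a plain pyridin-3-yl on the same carbonyl carbon would address. They also leave open whether the flat response holds beyond aromatic rings, for example with a saturated ring such as morpholine, a short alkyl chain or a group carrying a carboxylic acid in that place.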